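Swapping the Benzyl Ether Aryl Group in a Cytotoxicity Series

The compounds below may be only part of what the source reports. "The series", "measured", "known", "first", "only" and "open" are said of these compounds alone.

Of the compounds shown here, three sharing one core have been measured in an ADME assay on MT4 cells (Homo sapiens) for cytotoxicity, read by MTT assay, with a stated time of 5 days; a higher number here means that more compound is tolerated, a lower number that less compound is tolerated. Compound 1 `N#Cc1ccc(Nc2nccc(OCc3ccc(Cl)cc3)n2)cc1` gives 156000 nM, compound 2 `Cc1cccc(COc2ccnc(Nc3ccc(C#N)cc3)n2)c1` gives 30000 nM, and compound 3 `N#Cc1ccc(Nc2nccc(OCc3cccc(C(F)(F)F)c3)n2)cc1` gives 118000 nM. Compound 2 therefore stands at the lowest of the three numbers, with compound 3 nearest and compound 1 furthest from it; the two measured steps, a 5.2-fold lower number from compound 1 to compound 2 (0.72 log units; beyond the scatter) and a 3.9-fold higher number from compound 2 to compound 3 (0.59 log units; beyond the scatter), are both beyond the scatter, so compound 2 is the least tolerated of the three.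

Compound 4 `N#Cc1ccc(COc2ccnc(Nc3ccc(C#N)cc3)n2)cc1` is not yet measured. It differs from compound 2 in one place: 4-cyanophenyl in place of 3-methylphenyl on a saturated chain carbon bound to an oxygen on an aromatic ring. Both known steps alter the same aryl group on the same saturated chain carbon bound to an oxygen on an aromatic ring, and in both directions away from compound 2 the number in this assay rose by a modest amount. Neither step places a 4-cyanophenyl there, so the exact size is open, but the pattern of the two steps points upward rather than downward.

He therefore expects a modest increase, a 3.0-fold higher number from compound 2 to compound 4 (0.48 log units; beyond the scatter), and estimates compound 4 at 90000 nM, within a range from 35000 nM to 230000 nM.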

Compound 4, half-maximal cytotoxic concentration: 209000 nM
Compound 4: middle estimate off by 2.3-fold (0.37 log units), on the low side, and the stated range covers the measured number.
By their numbers in this assay, from the lowest: compound 2; then compounds 3, 1 and 4 (each within the scatter of the next).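

At this position, 4-cyanophenyl in place of 3-methylphenyl brings a 7.0-fold higher number from compound 2 to compound 4 (0.84 log units; beyond the scatter) in this assay, so each of the three other aryl groups now sits beyond the scatter from compound 2, and none of the compounds shown goes against this. Within the data shown here, the new compound also gives the first step that stays within the scatter, a 1.3-fold higher number from compound 1 to compound 4 (0.13 log units; within the scatter), so that cyano in place of chloro on an aromatic carbon cannot be told apart here. Of the pairs that differ in one place, then, only those involving compound 2 show a real difference, and compound 2 remains the least tolerated of the four. Nothing at hand bears on the reason for these numbers.

The compounds shown leave open whether the low number of compound 2 goes with its methyl group as such or with the particular 3-methylphenyl arrangement, since a 4-methylphenyl or a plain phenyl group does not appear among them. As far as these compounds go, how an amine or a carboxylic acid on this aryl ring would read in this assay also remains open.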